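Replacing Methoxymethyl with Phenyl on the Shared Core

This account rests on a few compounds, and the source may have more. Where it says the series, first, only, none or still open, it means among the compounds named here.

The measured compounds:
compound 1, `OCc1cc2cc(/C(=N\O)Nc3cccc(Cl)c3)ccc2o1`, 8000 nM
compound 2, `COCc1cc2cc(/C(=N\O)Nc3cccc(Cl)c3)ccc2o1`, 1000 nM
compound 3, `COCc1cc2cc(/C(=N\O)Nc3cccc(Br)c3)ccc2o1`, 930 nM

All three were tested in an assay on isolated protein for inhibition of Indoleamine 2,3-dioxygenase 1 (Homo sapiens), read by spectrophotometry; a lower number here means a stronger inhibitor, a higher number a weaker inhibitor. Among them compound 2 stands second highest, with compound 3 nearest and compound 1 furthest away. Two single changes are shown. The step of an 8.0-fold lower number from compound 1 to compound 2 (0.90 log units; beyond the scatter) is beyond the scatter, so exchanging the group on the five-membered ring of the shared core does move the number. The step of a 1.1-fold lower number from compound 2 to compound 3 (0.03 log units; within the scatter) lies within the scatter.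

Compound 4, `O/N=C(/Nc1cccc(Cl)c1)c1ccc2oc(-c3ccccc3)cc2c1`, has not yet been measured. It differs from compound 2 by phenyl in place of methoxymethyl on an aromatic carbon. Going by the values given here, no measured step covers this particular exchange. Among the compounds with values here, the only step that bears on it is the one from compound 1 to compound 2, which shows that this position responds to change; the step from compound 2 to compound 3 is at a different place and is within the scatter, so it adds nothing here. The direction cannot be read from the data.

Compound 4 is therefore expected to show 800 nM, within a range from 150 nM to 4000 nM, which would mean an estimated step of a 1.3-fold lower number from compound 2 to compound 4 (0.10 log units; within the scatter) in this assay.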

Compound 4, half-maximal inhibitory concentration: 900 nM
The estimate for compound 4 lay 1.1-fold (0.05 log units) below the measured number; the range from low to high includes it.
By their numbers in this assay, from the lowest: compounds 4, 3 and 2 (each within the scatter of the next); then compound 1.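

In this assay, the exchange of methoxymethyl for phenyl on the aromatic carbon next to the ring oxygen gives a 1.1-fold lower number from compound 2 to compound 4 (0.05 log units; within the scatter), so this place accepts a six-membered aromatic ring of carbon only, with no hydrogen-bond acceptor, as readily as the open-chain methoxymethyl group that carries one. The second new step, an 8.9-fold lower number from compound 1 to compound 4 (0.95 log units; beyond the scatter), is beyond the scatter, so among the three groups seen at this place, only hydroxymethyl stands apart with a clearly higher number, while two quite different groups give numbers within the scatter of each other. Nothing measured here explains why hydroxymethyl differs from the other two groups, or why methoxymethyl and phenyl end up so close.

Going by these compounds, what happens with an amine, a carboxylic acid or a longer carbon chain at this place remains open, as does whether a phenyl ring bearing a chloro or methoxy group would change the number. Also open, on these data alone, is whether bromo in place of chloro on the other aromatic ring would again stay within the scatter when phenyl is present on the shared core.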